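The source may report more compounds than this note shows. Statements on the series, on what has been measured and on what is new or still open speak of the compounds shown alone.

Measured compounds:
- compound 1, `N#CSCCCc1c[nH]c2ccc(F)cc12`: 5 nM
- compound 2, `NCCCCc1c[nH]c2ccc(C(=O)O)cc12`: "not active" (no number reported)

In an assay on isolated protein (urine) for inhibition of Myeloperoxidase (Homo sapiens), with a stated time of 5 min (on this read-out higher numbers stand for weaker inhibition and lower numbers for stronger inhibition), compound 1 gives 5 nM, the only numerical result in the series. Going by the values given here, the other measured entry differs from compound 1 in more than one place; in this assay compound 2 is reported as "not active" (no number reported), without a number, so no single step between measured compounds can be read from the two.

The unmeasured compound 3, `CCNC(=O)CCCc1c[nH]c2ccc(F)cc12`, keeps the core of compound 1 and differs only in the side chain: ethylcarbamoyl in place of cyanosulfanyl on a saturated chain carbon, three bonds along the chain from an aromatic carbon. Among the compounds with values here, no measured pair isolates this kind of exchange, so its effect on this assay has to be guessed. Within the data shown here, the only group that has changed is the one that leaves; the result for compound 1 in this assay is the sole anchor, and a large move in the weaker direction, beyond the scatter, is expected. The step expected from compound 1 to compound 3 is a 1000-fold higher number from compound 1 to compound 3 (3.00 log units; beyond the scatter). Compound 3 is accordingly estimated at 5000 nM, with a range from 500 nM to 50000 nM, and a real chance that only a limit is reported.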

Compound 3, half-maximal inhibitory concentration: 182 nM
Compound 3: middle estimate off by 27-fold (1.44 log units), on the high side, and the stated range ends above it.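

Going by these compounds alone, replacing cyanosulfanyl with ethylcarbamoyl on a saturated chain carbon, three bonds along the chain from an aromatic carbon, gives a 36-fold higher number from compound 1 to compound 3 (1.56 log units; beyond the scatter) in this assay and provides the first numerical reading of a change at this position. The step is beyond the scatter, but compound 3 still gives 182 nM in this read-out, so on the core of compound 1 a measurable value does not depend on keeping the cyanosulfanyl group. No measurement available here bears on the reason for the size of this step.

Within the data shown here, compound 2 differs from both compound 1 and compound 3 in more than one place and carries no number, so no step involving it can be read, and its "not active" result cannot be assigned to either its amine-ended chain or its carboxylic acid on the core. As far as these compounds go, it remains open how a simple amide without the ethyl group, a plain amine, a carboxylic acid or a longer chain at this same position would compare with cyanosulfanyl and ethylcarbamoyl on the fluorine-bearing core.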